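The compounds below may be only part of what the source reports. "The series", "measured", "known", "first", "only" and "open" are said of these compounds alone.

Compound 1 `CC(C)=CCC/C(C)=C/C[C@]12C[C@@H](CC=C(C)C)C(C)(C)[C@](CC=C(C)C)(C(=O)CC1=O)C2=O` is the starting point of this account. In a functional assay on SGC-7901 cells (Homo sapiens) for inhibition (a higher number here means a weaker inhibitor, a lower number a stronger inhibitor), compound 1 gives 5.6 ug/mL. Compound 2 `CC(C)=CCC/C(C)=C/C[C@@H]1C[C@]2(CC=C(C)C)C(=O)[C@@](CC=C(C)C)(C(=O)C(C(=O)c3ccc(O)c(O)c3)=C2O)C1(C)C` has another core, and the difference between the two cores is not broken down here. In this assay compound 2 reaches only a limit, > 20 ug/mL, which is the limit of > 20 ug/mL in this assay, at which 1 of the 3 values shown sits. Compound 3 `CC(C)=CCC/C(C)=C/C[C@@H]1C[C@]2(C/C=C(\C)CCC=C(C)C)C(=O)[C@@](CC=C(C)C)(C(=O)C(C(=O)c3ccc(O)c(O)c3)=C2O)C1(C)C` differs from compound 2 by 3-methylbut-2-en-1-yl in place of hydrogen on a saturated chain carbon bound to a double-bonded chain carbon. In this assay compound 3 gives 4.05 ug/mL, which amounts to an at least 4.9-fold lower number from compound 2 to compound 3 (0.69 log units; beyond the scatter). Compound 4 `CC(C)=CCC/C(C)=C/C[C@]12C[C@@H](CC=C(C)C)C(C)(C)[C@](C/C=C(\C)CCC=C(C)C)(C(=O)CC1=O)C2=O` differs from compound 1 by 3-methylbut-2-en-1-yl in place of hydrogen on a saturated chain carbon bound to a double-bonded chain carbon, the same change made on the same kind of carbon. Because the step of an at least 4.9-fold lower number from compound 2 to compound 3 (0.69 log units; beyond the scatter) begins at a limit its true size is not known, so compound 4 is expected to sit only modestly lower than compound 1, a step estimated as a 2.2-fold lower number from compound 1 to compound 4 (0.35 log units; beyond the scatter). Compound 4 is therefore expected to give 2.5 ug/mL, likely between 1 ug/mL and 8 ug/mL.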

Compound 4, half-maximal inhibitory concentration: > 20 ug/mL
Compound 4: a limit, no number (the forecaster's own chance of this, stated with the estimate: 5%); middle value at least 8.0-fold (0.90 log units) away from the limit.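

In this assay compound 4 reaches only a limit, > 20 ug/mL. The added 3-methylbut-2-en-1-yl therefore goes with an at least 3.5-fold higher number from compound 1 to compound 4 (0.55 log units; beyond the scatter), and the change does not carry over from one core to the other: the same change on two cores in this assay, an at least 4.9-fold lower number (0.69 log units; beyond the scatter) from compound 2 to compound 3 and an at least 3.5-fold higher number (0.55 log units; beyond the scatter) from compound 1 to compound 4, at least 17-fold (1.24 log units) apart, beyond the scatter of two such steps. From the compounds shown here alone, this shows that the direction of the step differs between these two pairs, but each step rests on a limit, so its true size stays unknown, and two pairs give no rule for other cores.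

Still open, going by these compounds, is how a shorter saturated chain such as 3-methylbutyl would read on either core in place of the 3-methylbut-2-en-1-yl. The same holds for a chain carrying an amine or a carboxylic acid.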